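A few compounds are considered here, and "the series" means these few. Any claim that something is new, unique, unknown or untested is made for them only; others in the source may bear on it.

For the measured compounds named here, compound 2 `CC1CCN(C2CCN(S(=O)(=O)c3cccc(Br)c3)CC2)CC1` sits at the lower of the two numbers measured so far in a functional assay on DLD-1 cells (Homo sapiens) for antiproliferative activity, read by CellTiter-Glo, with a stated time of 72 h (a lower number here means a stronger inhibitor, a higher number a weaker inhibitor), where compound 2 gives 3.2 nM. Its nearest neighbour is compound 1 `CC1CCN(C2CCN(S(=O)(=O)c3cccc(N)c3)CC2)CC1`, which in this assay gives 3400 nM; the difference a 1100-fold lower number from compound 1 to compound 2 (3.03 log units; beyond the scatter) is large. The untested compound 3 `Cc1ccc(-c2cccc(S(=O)(=O)N3CCC(N4CCC(C)CC4)CC3)c2)cc1` differs from compound 2 in one place: 4-methylphenyl in place of bromo on an aromatic carbon. Going by the values given here, only one measured step touches this same aromatic carbon, and it is a 1100-fold lower number from compound 1 to compound 2 (3.03 log units; beyond the scatter), so that position clearly matters, but swapping bromo for 4-methylphenyl is a different exchange, and nothing measured shows its direction. The expectation is therefore a step of modest size, most likely toward a higher number, written as a 9.4-fold higher number from compound 2 to compound 3 (0.97 log units; beyond the scatter). On that basis compound 3 is estimated at 30 nM in this assay, with a plausible range from 3 nM to 300 nM.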

Compound 3, half-maximal inhibitory concentration: 11 nM
Compound 3: middle estimate off by 2.7-fold (0.44 log units), on the high side; the range from low to high includes it.
By their numbers in this assay, from the lowest: compound 2; then compound 3; then compound 1.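

In this assay, exchanging the single bromine atom for 4-methylphenyl, a group of 7 heavy atoms with its own aromatic ring, gives a 3.4-fold higher number from compound 2 to compound 3 (0.54 log units; beyond the scatter) and leaves the number low, so this aromatic carbon can carry a far larger group at a modest cost. Set against amino, the same group gives a 310-fold lower number from compound 1 to compound 3 (2.49 log units; beyond the scatter), which shows that the large gain seen with bromo is not unique to bromo: two very different replacements for amino both end far below compound 1. No available evidence explains why amino stands so far from the other two groups. From the compounds shown here alone, it remains open whether the methyl on the added ring contributes anything, which plain phenyl would test. Also untested among these compounds are smaller groups such as chloro or methyl, and a carboxylic acid at this carbon.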